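This account rests on a few compounds, and the source may have more. Where it says the series, first, only, none or still open, it means among the compounds named here.

Of the compounds shown here, three built on one shared core have been measured so far, and they differ from one another only in the aryl group that sits on a double-bonded chain carbon bound to an aromatic carbon. In a functional assay on MCF7 cells (Homo sapiens) for cytotoxicity, read by CCK-8 assay, with a stated time of 72 h (a higher number here means a weaker inhibitor, a lower number a stronger inhibitor), compound 1 `C=CCn1c(=O)/c(=C\c2cccc(F)c2)[nH]c(=O)/c1=C\c1ccccc1OC` gives 13700 nM, which is a weak result in itself. Compound 2 `C=CCn1c(=O)/c(=C\c2ccc(F)c(Br)c2)[nH]c(=O)/c1=C\c1ccccc1OC` is reported in this assay as "not active" (no number reported), with no number attached. Compound 3 `C=CCn1c(=O)/c(=C\c2ccc(C)cc2)[nH]c(=O)/c1=C\c1ccccc1OC` likewise stands in this assay at "not active" (no number reported), so no single value places it on the scale; it is one of two compounds here for which only an outcome and no number was reported, and only compound 1 carries a numerical result.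

Compound 4 `C=CCn1c(=O)/c(=C\c2cc(F)ccc2C)[nH]c(=O)/c1=C\c1ccccc1OC` is the compound not yet measured. Its change from compound 3 is 5-fluoro-2-methylphenyl in place of 4-methylphenyl on a double-bonded chain carbon bound to an aromatic carbon. Among the compounds with values here, no measured pair in this set shows what such a change does, so no step size can be read off. Given that compound 3 gives "not active" (no number reported) in this assay and that the one numerical result, from compound 1, is 13700 nM, compound 4 is expected to remain weak, with a fair chance that this assay again reports no number. Compound 4 is estimated at 25000 nM in this assay, within a range from 8000 nM to 80000 nM.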

Compound 4, half-maximal inhibitory concentration: 3100 nM
The estimate for compound 4 lay 8.1-fold (0.91 log units) above the measured number; the measured number lies below the stated range.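

In this assay, within the data shown here, methyl in place of hydrogen on an aromatic carbon gives a 4.4-fold lower number from compound 1 to compound 4 (0.65 log units; beyond the scatter), the first step in this set that can be read as a number, and it lies beyond the usual scatter. It shows that a single added methyl on the aryl group at this place, on a double-bonded chain carbon bound to an aromatic carbon, can shift the result, and that with 5-fluoro-2-methylphenyl compound 4 gives 3100 nM, whereas compound 3, with 4-methylphenyl, was reported as not active and has no place on the scale. Nothing measured here gives a reason for this shift.

Steps that involve compound 2 or compound 3 cannot be read, as both are reported without a number, so the effect of moving the methyl or the fluorine around the aryl group remains unknown. Going by these compounds, it also remains open how an amine, a carboxylic acid or a longer chain such as ethyl in place of that methyl would read in this assay.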